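Aryl to ester swap on the ring nitrogen: toxicity expectation

The source may hold more compounds than are shown below. What is called first, only, known or untested is meant among the compounds shown, and "the series" means these compounds.

Measured so far:
Compound 1 `Cc1ccccc1-c1nn(-c2ccccc2Cl)cc1CNCCN1CCN(C)CC1` — > 20000 nM
Compound 2 `Cc1ccccc1-c1nn(-c2ccc(F)cc2)cc1CNCCN1CCN(C)CC1` — > 20000 nM

In an ADME assay on Huh-7 cells (Homo sapiens) for cytotoxicity (on this read-out lower numbers stand for higher toxicity in this test and higher numbers for lower toxicity in this test), compound 1 gives > 20000 nM, which is a limit of the assay rather than a number. Compound 2 likewise gives > 20000 nM, again a limit and not a number. Among the compounds with values here, the single measured step, a step that the two limits leave unreadable from compound 1 to compound 2, therefore cannot be sized, since the limit of > 20000 nM in this assay, at which 2 of the 2 values shown sit, covers both values. Compound 2 thus stands only at a limit, with no numeric value of its own.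

Compound 3 `CCOC(=O)Cn1cc(CNCCN2CCN(C)CC2)c(-c2ccccc2C)n1` differs from compound 2 by (ethoxycarbonyl)methyl in place of 4-fluorophenyl on an aromatic nitrogen. Within the data shown here, no measured step bears directly on this change: the only step available compares two aryl groups on the same nitrogen and is itself unreadable. With both measured compounds sitting at the limit of the assay, the expectation is that compound 3 stays there too, so the estimated step that the limit leaves unreadable from compound 2 to compound 3 is none beyond the scatter. Compound 3 is accordingly estimated at 30000 nM, between 10000 nM and 100000 nM, with a good chance that only a limit is reported once more.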

Compound 3, half-maximal cytotoxic concentration: > 20000 nM
Compound 3 ended at the assay's limit; the forecaster's own chance of this, stated with the estimate: 75%; the middle value is on the limit's open side.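

Within the data shown here, no step among compound 1, compound 2 and compound 3 can be read in this assay, since all three stand at a limit and not at a number: the limit of > 20000 nM in this assay, at which 3 of the 3 values shown sit. The compounds shown leave open how far apart compound 1, compound 2 and compound 3 lie in this assay, and whether the group on the aromatic nitrogen makes any difference there.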